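This account rests on a few compounds, and the source may have more. Where it says the series, first, only, none or still open, it means among the compounds named here.

- Compound 1 `COc1cccc(NC(=O)Oc2cccc3cccnc23)c1`: < 7000 nM
- Compound 2 `CC(NC(=O)Oc1cccc2cccnc12)c1ccccc1`: < 35000 nM
- Compound 3 `COc1ccccc1OC(=O)Nc1cccc2cccnc12`: < 30000 nM

All three values come from a functional assay for inhibition, with Rattus norvegicus as the target (on this read-out lower numbers stand for stronger inhibition and higher numbers for weaker inhibition), and none of them is an exact number. Compound 2 gives < 35000 nM, which is a limit of the assay. Compound 1 gives < 7000 nM, which is also a limit. Compound 3 gives < 30000 nM, again a limit. Compound 2 therefore has no exact position on the scale, and these three compounds cannot be ranked.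

The next compound is compound 4 `C[C@@H](NC(=O)Oc1cccc2cccnc12)c1ccccc1`. The change from compound 2 is the two compounds have the same atoms and bonds; at least one stereo element is drawn with a configuration in one of them and without one in the other: 1 of 1 stereo elements differ; a stereocentre at a saturated chain carbon is drawn without a configuration in compound 2 and R in compound 4. The two compounds have the same atoms and bonds, and only the drawn configuration differs.

Among the compounds with values here, no measured pair here shows what such a change does in this assay. With the same atoms and bonds, no step beyond the usual scatter is expected, though any small shift is expected towards stronger inhibition. The estimate for this change is a step that the limit leaves unreadable from compound 2 to compound 4. Compound 4 is expected to give 20000 nM. The estimated range for compound 4 runs from 5000 nM to 35000 nM.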

Compound 4, half-maximal inhibitory concentration: < 35000 nM
Compound 4: only a limit was reported; the forecaster's own chance of this, stated with the estimate: 50%; the middle value does not contradict the limit.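

In this assay compound 4 gives < 35000 nM, which is a limit. Compound 2 gives < 35000 nM, also a limit, and no step can be read between these two compounds. The compounds shown leave open whether drawing the stereocentre as R changes inhibition at all.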